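Swapping the Amide-Bearing Ring for a Benzoxazole

This account rests on a few compounds, and the source may have more. Where it says the series, first, only, none or still open, it means among the compounds named here.

Compound 2 `NC(=O)c1cccc(-c2cc(C(O)(C(F)(F)F)C(F)(F)F)cnc2N2CCN(S(=O)(=O)c3ccc(N)nc3)CC2)c1` stands at the lower end of the two numbers in an ADME assay (liver) for metabolic stability, with Liver microsome (Homo sapiens) as the target, using microsomes and NADPH, with a stated time of 30 min, tested at 1 uM; on this read-out lower numbers stand for slow clearance and higher numbers for fast clearance. In this assay compound 2 gives 17 mL.min-1.g-1, and compound 1 `Nc1ccc(S(=O)(=O)N2CCN(c3ncc(C(O)(C(F)(F)F)C(F)(F)F)cc3-c3cccc(F)c3)CC2)cn1` gives 25 mL.min-1.g-1, so that a 1.5-fold lower number from compound 1 to compound 2 (0.17 log units; within the scatter) lies within the scatter. Compound 3 `Nc1ccc(S(=O)(=O)N2CCN(c3ncc(C(O)(C(F)(F)F)C(F)(F)F)cc3-c3ccc4ocnc4c3)CC2)cn1` differs from compound 2 by 1,3-benzoxazol-5-yl in place of 3-carbamoylphenyl on an aromatic carbon. Going by the values given here, no measured step touches this group; the only step known, a 1.5-fold lower number from compound 1 to compound 2 (0.17 log units; within the scatter), changes a different part and was small, so no step beyond the scatter is expected. The expected step is a 1.2-fold higher number from compound 2 to compound 3 (0.07 log units; within the scatter). Compound 3 is therefore estimated at 20 mL.min-1.g-1, between 8 mL.min-1.g-1 and 50 mL.min-1.g-1.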

Compound 3, intrinsic clearance in microsomes: < 14 mL.min-1.g-1
Compound 3: only a limit was reported; the forecaster's own chance of this, stated with the estimate: 5%; middle value at least 1.4-fold (0.15 log units) from the limit.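

Replacing 3-carbamoylphenyl gives an at least 1.2-fold lower number from compound 2 to compound 3 (0.08 log units; that floor lies within the scatter) and replacing 3-fluorophenyl gives an at least 1.7-fold lower number from compound 1 to compound 3 (0.25 log units; that floor lies within the scatter) in this assay and so this position accepts 1,3-benzoxazol-5-yl, with its 0 hydrogen-bond donors, with no sign of faster clearance. The entry for compound 3 is a limit, not a number: the limit of < 14 mL.min-1.g-1 in this assay, at which 1 of the 3 values shown sits. Going by these compounds, how far compound 3 lies beyond its limit therefore stays open. Also open, on these data alone, is whether a nitrile or a carboxylic acid on the phenyl ring at this position would give a similar clearance.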